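Chain lengthening at the hydroxamic acid end

The source may hold more compounds than are shown below. What is called first, only, known or untested is meant among the compounds shown, and "the series" means these compounds.

Measured in a functional assay on A549 cells (Homo sapiens) for inhibition, read by MTT assay, with a stated time of 72 h (on this read-out lower numbers stand for stronger inhibition and higher numbers for weaker inhibition), as follows:
- compound 1 `Nc1nc2cc(-c3nn(CCC(=O)NO)c4ncnc(N)c34)ccc2o1` reads > 150000 nM as a limit
- compound 2 `Nc1nc2cc(-c3nn(CCCCC(=O)NO)c4ncnc(N)c34)ccc2o1` reads > 100000 nM as a limit

Compound 2 has no number on this read-out, and its reading of > 100000 nM is only a limit. The other value shown, for compound 1, is also a limit.

Compound 3 `Nc1nc2cc(-c3nn(CCCCCCCCC(=O)NO)c4ncnc(N)c34)ccc2o1` carries 4-(hydroxycarbamoyl)butyl in place of hydroxycarbamoyl on a saturated chain carbon, four bonds along the chain from an aromatic nitrogen, counted as 4-(hydroxycarbamoyl)butyl in place of hydroxycarbamoyl on a saturated chain carbon, four bonds along the chain from an aromatic nitrogen in this change.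

Among the compounds with values here, the one measured step, a step that the two limits leave unreadable from compound 1 to compound 2, has no readable size and sets no scale here. A readable value in this assay could only lie on the stronger side of the limit of compound 2, so a move in that direction is expected, though another limit remains quite possible.

The estimated value of compound 3 is 20000 nM within an expected range of 2000 nM to 100000 nM on this estimate. The expected step of an at least 5.0-fold lower number from compound 2 to compound 3 (0.69 log units; beyond the scatter) is loose for that reason.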

Compound 3, half-maximal inhibitory concentration: 13200 nM
The estimate for compound 3 lay 1.5-fold (0.18 log units) above the measured number; measured number inside the range.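

Lengthening the chain at this position gives a readable number in this assay for the first time, with an at least 7.5-fold lower number from compound 2 to compound 3 (0.87 log units; beyond the scatter) and, across the whole change from the shortest chain, with an at least 11-fold lower number from compound 1 to compound 3 (1.05 log units; beyond the scatter). The first of these steps gives only a minimum size, because compound 2 stands at a limit: the limit of > 100000 nM in this assay, at which 1 of the 3 values shown sits. The second gives only a minimum size, because compound 1 also stands at a limit: the limit of > 150000 nM in this assay, at which 1 of the 3 values shown sits.

The step between the two shorter chains cannot be read, so the compounds shown do not establish whether the effect of chain length builds gradually or appears only at the chain of compound 3. Also open, going by these compounds, are whether a longer chain would lower the number further and whether a carboxylic acid in place of hydroxycarbamoyl on the chain of compound 3 would keep a readable value.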